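Pentyloxy for Isopropylamino: What the Limits Allow

This account rests on a few compounds, and the source may have more. Where it says the series, first, only, none or still open, it means among the compounds named here.

Three measured compounds share one core: compound 1 `C=CCOc1nc(N)nc2c1ncn2/C=C1/CC1(CO)CO`, compound 2 `CC(C)Nc1nc(N)nc2c1ncn2/C=C1/CC1(CO)CO` and compound 3 `Nc1nc2c(ncn2/C=C2/CC2(CO)CO)c(=O)[nH]1`. In an ADME assay on CCRF-HSB-2 cells (Homo sapiens) for cytotoxicity, with a stated time of 7 days (on this read-out higher numbers stand for lower toxicity in this test and lower numbers for higher toxicity in this test), compound 1 gives only a limit, > 20000 nM. Compound 2 likewise reaches only a limit in this assay, namely > 20000 nM. Compound 3 also stops at a limit in this assay, > 20000 nM. Going by the values given here, the single step between neighbouring measured compounds, a step that the two limits leave unreadable from compound 1 to compound 2, is left unreadable by the two limits. The whole picture is the limit of > 20000 nM in this assay, at which 3 of the 3 values shown sit, so compound 2 stands at the limit with every other value shown.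

Compound 4 `CCCCCOc1nc(N)nc2c1ncn2/C=C1/CC1(CO)CO` is not yet measured. It differs from compound 2 by pentyloxy in place of isopropylamino on an aromatic carbon. Among the compounds with values here, no measured step can be sized, so none gives a direction for this change; the three limits simply agree. The step that the limit leaves unreadable from compound 2 to compound 4 is therefore expected to lie within the scatter, with compound 4 staying at the limit. Compound 4 is estimated at 25000 nM in this assay, with a range from 8000 nM to 100000 nM.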

Compound 4, half-maximal cytotoxic concentration: > 20000 nM
Compound 4: only a limit was reported; the forecaster's own chance of this, stated with the estimate: 80%; the middle value is on the limit's open side.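

Compound 4, like compound 1 and compound 2, gives only a limit, and neither step to compound 4 from those two compounds can be read. In this assay the compounds shown leave open the size and even the direction of every change among them.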